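A few compounds are considered here, and "the series" means these few. Any claim that something is new, unique, unknown or untested is made for them only; others in the source may bear on it.

Working notes on the coumarin-amide series, antiproliferative read-out.

Of the compounds shown here, three have numbers so far. Compound 1 `CC(C)=CCc1cc(C(=O)Nc2cc3ccc(OCC4CCCNC4)c(C)c3oc2=O)ccc1O` gives 790 nM in a functional assay on MCF7 cells (Homo sapiens) for antiproliferative activity; a higher number here means a weaker inhibitor, a lower number a stronger inhibitor. Compound 2 `CCN(CC)CCCOc1ccc2cc(NC(=O)c3ccc(O)c(CC=C(C)C)c3)c(=O)oc2c1C` gives 6390 nM in this assay, and compound 3 `CC(C)=CCc1cc(C(=O)Nc2cc3ccc(OCCCNC(C)C)c(C)c3oc2=O)ccc1O` gives 740 nM in this assay. Compound 3 therefore holds the lowest number of the three, though its nearest neighbour is compound 1: a 1.1-fold lower number from compound 1 to compound 3 (0.03 log units; within the scatter), so the two cannot be ordered. Against compound 2 the gap is clear: an 8.6-fold lower number from compound 2 to compound 3 (0.94 log units; beyond the scatter), and likewise an 8.1-fold higher number from compound 1 to compound 2 (0.91 log units; beyond the scatter).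

The next compound, compound 4 `CC(C)=CCc1cc(C(=O)Nc2cc3ccc(OCCCNc4ccccc4)c(C)c3oc2=O)ccc1O`, differs from compound 3 only at the amine nitrogen: phenyl in place of isopropyl on an amine nitrogen.

For the measured compounds named here, no measured step swaps isopropyl for phenyl on that nitrogen. The steps that touch the same amine show two things: changing the substituents on the nitrogen can move the number by a modest amount (an 8.6-fold lower number from compound 2 to compound 3 (0.94 log units; beyond the scatter)), while another change at that position leaves it within the scatter (a 1.1-fold lower number from compound 1 to compound 3 (0.03 log units; within the scatter)). A modest step in this assay is therefore plausible for compound 4, but its direction cannot be read from the data, and the range must be set wide.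

For compound 4 the estimate is 2000 nM in this assay, with a range from 600 nM to 8000 nM, meaning an expected step of a 2.7-fold higher number from compound 3 to compound 4 (0.43 log units; beyond the scatter).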

Compound 4, half-maximal inhibitory concentration: > 50000 nM
Compound 4: only a limit was reported; the forecaster's own chance of this, stated with the estimate: 5%; middle value at least 25-fold (1.39 log units) from the limit.
By their numbers in this assay, from the lowest: compounds 3 and 1 (each within the scatter of the next); then compound 2. At a limit, above all of these: compound 4.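

In this assay the result for compound 4 is a limit of the assay and not a number: the limit of > 50000 nM in this assay, at which 1 of the 4 values shown sits.

Phenyl in place of isopropyl on an amine nitrogen gives an at least 67-fold higher number from compound 3 to compound 4 (1.82 log units; beyond the scatter), a large step, whereas the widest gap among the earlier amines was an 8.6-fold lower number from compound 2 to compound 3 (0.94 log units; beyond the scatter), so this nitrogen tolerates far less change than those compounds showed. The anilino compound also separates from both other amines, with an at least 7.8-fold higher number from compound 2 to compound 4 (0.89 log units; beyond the scatter) and an at least 63-fold higher number from compound 1 to compound 4 (1.80 log units; beyond the scatter); among the compounds shown, compound 4 alone carries an aromatic ring directly on the amine nitrogen, although compound 2 shows that saturated carbon groups there do not all give the same number.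

The compounds shown leave open whether the sharp drop follows from the aromatic ring sitting directly on the nitrogen or from the size of the six-carbon group, a question that a benzyl or a cyclohexyl group on the same nitrogen would address. Going by these compounds, how far each of the three steps extends past its printed minimum also stays open.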